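The source may hold more compounds than are shown below. What is called first, only, known or untested is meant among the compounds shown, and "the series" means these compounds.

Measured so far:
compound 1 `CC(C)N1CCc2nc(C#Cc3ccccn3)ccc2C1=O` — 27 nM
compound 2 `CC(C)N1CCc2nc(C#Cc3cccnc3)ccc2C1=O` — "not active" (no number reported)

Compound 2 stands without a single number: in a functional assay on HEK293 cells for negative allosteric modulation of metabotropic glutamate receptor 5 (Homo sapiens), read by FLIPR and calcium flux (on this read-out higher numbers stand for weaker inhibition and lower numbers for stronger inhibition), compound 2 is recorded as "not active" (no number reported), while compound 1 gives 27 nM. Compound 3 `CC(C)N1CCc2nc(C#Cc3cccs3)ccc2C1=O` carries thiophen-2-yl in place of pyridin-3-yl on a triple-bonded carbon, so the change is thiophen-2-yl in place of pyridin-3-yl on a triple-bonded carbon. Among the compounds with values here, no measured step covers this pair. The account expects compound 3 to move toward a measurable, stronger result than compound 2 in this assay, beyond the scatter, though with wide uncertainty. For compound 3 the expected value is 150 nM, with a range from 20 nM to 3000 nM.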

Compound 3, half-maximal inhibitory concentration: 45 nM
Estimate against measurement, compound 3: 3.3-fold (0.52 log units) above; measured number inside the range.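

In this assay compound 3 with thiophen-2-yl on the triple-bonded carbon gives 45 nM while compound 2 with pyridin-3-yl there is recorded as "not active" (no number reported) on the same read-out. Thiophen-2-yl in place of pyridin-2-yl gives a 1.7-fold higher number from compound 1 to compound 3 (0.22 log units; within the scatter) so a ring nitrogen is not required at this place. No evidence is available that explains these results. Going by these compounds, whether furan-2-yl, thiazol-2-yl or a plain phenyl ring would hold up on the triple-bonded carbon stays open. So does the reading for a cyclopropyl group in place of the isopropyl group on the shared core.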